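Capping the carboxy group of compound 2 with methyl

The source may hold more compounds than are shown below. What is called first, only, known or untested is meant among the compounds shown, and "the series" means these compounds.

Measured so far in a functional assay on SF-539 cells (Homo sapiens) for antiproliferative activity; on this read-out higher numbers stand for weaker inhibition of growth and lower numbers for stronger inhibition of growth:
compound 1 `CCCCCCNC(=O)c1cc(C#Cc2cc(OC)ccc2OC)ccc1OC` gives > 100000 nM as a limit of the assay
compound 2 `COc1ccc(OC)c(C#Cc2ccc(OC)c(C(=O)O)c2)c1` gives 38500 nM as a measured number
compound 3 `CCCCCCNC(=O)c1cc(/C=C\c2cc(OC)ccc2OC)ccc1OC` gives 23600 nM as a measured number

Compound 2 lies within the usual scatter of compound 3, so these two cannot be ranked. Compound 1 gave only a limit and not a number.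

Compound 4 `COC(=O)c1cc(C#Cc2cc(OC)ccc2OC)ccc1OC` differs from compound 2 by methyl in place of hydrogen on an oxygen next to a carbonyl group, which turns carboxy into methoxycarbonyl. Within the data shown here, the one measured step at this carbonyl is an at least 2.5-fold lower number from compound 1 to compound 2 (0.41 log units; beyond the scatter) and it put hydroxy in place of hexylamino. That step shows that the read-out can move with a change here. However, its size is only a bound and it involves a different group, so it sets no size for adding a methyl.

With compound 2 at 38500 nM as the anchor, no step beyond the scatter is expected. The estimated change is a 1.2-fold higher number from compound 2 to compound 4 (0.07 log units; within the scatter) in this assay and a weaker result remains possible. Compound 4 is expected at 45000 nM with an estimated range of 13000 nM to 100000 nM in this read-out.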

Compound 4, concentration for 50% growth inhibition: 81100 nM
For compound 4 the middle estimate is 1.8-fold (0.26 log units) below the measured one, and the stated range covers the measured number.
By their numbers in this assay, from the lowest: compounds 3 and 2 (each within the scatter of the next); then compound 4. At a limit, above all of these: compound 1.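

In this assay turning carboxy into methoxycarbonyl is a real though modest change, and it goes towards weaker inhibition of growth: there is a 2.1-fold higher number from compound 2 to compound 4 (0.32 log units; beyond the scatter) for this swap. Among these compounds, the earlier step at this carbonyl gave only a bound, whereas this one runs between two measured numbers, so it is the first step here with a definite size. The step to the methyl ester from the hexylamino amide is also only a bound: there is an at least 1.2-fold lower number from compound 1 to compound 4 (0.09 log units; that floor lies within the scatter) and the hexylamino amide cannot be placed against the methyl ester. Compound 1 gave only a limit: the limit of > 100000 nM in this assay, at which 1 of the 4 values shown sits.

The compounds shown leave open how an ethyl ester or a small amide, such as the one from methylamine, would read on this carbonyl. They also leave open whether the same swap of hydrogen for methyl would move the read-out the same way on the core of compound 3.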